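This account rests on a few compounds, and the source may have more. Where it says the series, first, only, none or still open, it means among the compounds named here.

Compound 2 `Cc1cc(Nc2cccc(Cl)c2)nc(N)n1` belongs to a small set that also holds compound 1 `CCc1cc(Br)cc(Nc2cc(C)nc(N)n2)c1`. In an assay on cells for inhibition of S-adenosylmethionine decarboxylase proenzyme (Homo sapiens), read by mass spectrometry, at pH 7.2 (on this read-out higher numbers stand for weaker inhibition and lower numbers for stronger inhibition), compound 2 gives only a limit, > 180000 nM. Compound 1 likewise gives only a limit there, > 180000 nM. Both values sit at the limit of > 180000 nM in this assay, at which 2 of the 2 values shown sit, so compound 2 stands at the same limit as its only companion. Compound 3 `Cc1cc(Nc2cccc(Br)c2)nc(N)n1` differs by bromo in place of chloro on an aromatic carbon. No step beyond the scatter is expected in this assay, so compound 3 is expected at 250000 nM, between 100000 nM and 600000 nM, and the change from compound 2 to compound 3 is estimated as a step that the limit leaves unreadable from compound 2 to compound 3.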

Compound 3, half-maximal inhibitory concentration: > 180000 nM
Compound 3 ended at the assay's limit; the forecaster's own chance of this, stated with the estimate: 85%; the middle value lies beyond the limit too.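

No step between compound 1, compound 2 and compound 3 can be read, as all three give only a limit: the limit of > 180000 nM in this assay, at which 3 of the 3 values shown sit. The compounds shown leave open whether bromo, chloro or ethyl makes any difference in this assay.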